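The compounds below may be only part of what the source reports. "The series", "measured", "known", "first", "only" and "open" are said of these compounds alone.

In a functional assay on HeLa cells (Homo sapiens) for antiproliferative activity, read by sulforhodamine B assay, with a stated time of 72 h (on this read-out lower numbers stand for stronger inhibition and higher numbers for weaker inhibition), compound 1 (`Fc1ccc(/C=C\c2cc3ccccc3nc2Cl)cc1`) gives 24900 nM. Compound 2 (`COc1ccc2nc(Cl)c(/C=C\c3ccc(C(F)(F)F)cc3)cc2c1`) gives 16200 nM, which lies within the usual scatter of the value for compound 1, so the two cannot be told apart on these numbers. Compound 3 (`COc1ccc2nc(Cl)c(/C=C\c3ccc(F)cc3)cc2c1`) has not yet been measured. It has fluoro in place of trifluoromethyl on an aromatic carbon, para to a large group: fluoro in place of trifluoromethyl on an aromatic carbon. Among the measured compounds shown here, no measured pair of compounds isolates a single change, so the data offer no direct guide to this replacement. For the measured compounds named here, the only reference points are compound 2 at 16200 nM and the similar value of compound 1. Accordingly, no shift beyond the scatter is expected in this assay, and the expected 1.1-fold lower number from compound 2 to compound 3 (0.03 log units; within the scatter) is small. For compound 3 the estimated value is 15000 nM, with an expected range of 6000 nM to 38000 nM.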

Compound 3, half-maximal inhibitory concentration: 9670 nM
Compound 3: middle estimate off by 1.6-fold (0.19 log units), on the high side; the measured number falls inside the stated range.
By their numbers in this assay, from the lowest: compounds 3, 2 and 1 (each within the scatter of the next, the first and the last beyond it).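

In this assay, fluoro in place of trifluoromethyl on the aromatic carbon gives a 1.7-fold lower number from compound 2 to compound 3 (0.22 log units; within the scatter) and stays within the scatter, so these two groups cannot be told apart at this position. With fluoro held constant, methoxy in place of hydrogen on an aromatic carbon gives a 2.6-fold lower number from compound 1 to compound 3 (0.41 log units; beyond the scatter), the first single change shown to lie beyond the scatter, though only modestly. No available evidence explains either step.

The compounds shown leave open whether an amine or a carboxylic acid on the aromatic carbon that carries fluoro or trifluoromethyl would shift the number beyond the scatter. They also leave open whether the methoxy step holds with trifluoromethyl in place of fluoro, and whether ethoxy would differ from methoxy.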